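Chloro in Place of Nitro on a Shared Core

The source may report more compounds than this note shows. Statements on the series, on what has been measured and on what is new or still open speak of the compounds shown alone.

Compound 1 `Nc1ccccc1NC(=O)c1ccc(NCC(=O)Nc2cccc([N+](=O)[O-])c2)cc1`, compound 2 `COc1ccc(NC(=O)CNCCCC(=O)Nc2ccccc2N)cc1` and compound 3 `Nc1ccccc1NC(=O)CCCNCC(=O)Nc1cccc([N+](=O)[O-])c1` share a common core. In a functional assay on HCT-116 cells (Homo sapiens) for inhibition, read by MTT assay, with a stated time of 2 days (on this read-out higher numbers stand for lower toxicity in this test and lower numbers for higher toxicity in this test), compound 1 reaches only a limit of the test, > 100000 nM. Compound 2 likewise gives only a limit, > 100000 nM. Compound 3 also stands at a limit, > 100000 nM, so no number places it among the others. The step that the two limits leave unreadable from compound 2 to compound 3 thus has no readable size. Compound 4 `Nc1ccccc1NC(=O)CCCNCC(=O)Nc1cccc(Cl)c1` differs from compound 3 by chloro in place of nitro on an aromatic carbon. Within the data shown here, no measured step bears on this change, and because the limit of > 100000 nM in this assay, at which 3 of the 3 values shown sit, is where every value sits, a number for compound 4 is unlikely. The step of a number no higher from compound 3 to compound 4 (the limit leaves the size open) is expected to stay within the scatter. Compound 4 is estimated at 100000 nM, between 30000 nM and 300000 nM.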

Compound 4, concentration lethal to 50% of the cells: > 100000 nM
Compound 4 gave a limit, no number; the forecaster's own chance of this, stated with the estimate: 80%; the middle value sits exactly at the limit.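

No new step can be read from compound 2 or compound 3 to compound 4, as each gives only a limit, not a number: the limit of > 100000 nM in this assay, at which 4 of the 4 values shown sit.

The compounds shown leave open whether chloro in place of nitro changes toxicity in this test at all.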